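A few compounds are considered here, and "the series" means these few. Any claim that something is new, unique, unknown or untested is made for them only; others in the source may bear on it.

In a functional assay on MKN-45 cells (Homo sapiens) for cytotoxicity, read by MTT assay, with a stated time of 72 h (on this read-out higher numbers stand for weaker inhibition and lower numbers for stronger inhibition), the three measured compounds stand as follows:

compound 1, `CN(C)CCCNc1nc(-c2ccc(NC(=O)Nc3ccc(Cl)cc3)cc2)nc2c(Cl)c(Cl)sc12`, gives 1530 nM
compound 2, `CN(C)CCCNc1nc(-c2ccc(NC(=O)Nc3ccc(Cl)cc3Cl)cc2)nc2c(Cl)c(Cl)sc12`, gives 2560 nM
compound 3, `CN(C)CCNc1nc(-c2ccc(NC(=O)Nc3ccccc3Cl)cc2)nc2c(Cl)c(Cl)sc12`, gives 1170 nM

Compound 4, `CN(C)CCNc1nc(-c2ccc(NC(=O)Nc3ccc(Cl)cc3Cl)cc2)nc2c(Cl)c(Cl)sc12`, has not yet been measured in this assay.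

Compound 1 and compound 2 differ in one place: chloro in place of hydrogen on an aromatic carbon. That change made a step of a 1.7-fold higher number from compound 1 to compound 2 (0.22 log units; within the scatter). Compound 3 carries a different core; the difference between the core of compound 1 and the core of compound 3 is not broken down here. On the measured numbers, compound 3 and compound 1 lie within the scatter of each other, while compound 2 lies beyond the scatter from compound 3.

Compound 4 arises from compound 3 by the same kind of change: chloro in place of hydrogen on an aromatic carbon. The surroundings are not identical, though. In the change from compound 1 to compound 2 the entering chloro sits ortho to a large group and meta to a chloro group; in the change from compound 3 to compound 4 it sits meta to a chloro group and para to a large group. For the measured compounds named here, with only one earlier instance of this kind of change, and that one within the scatter, the expectation rests on compound 3 at 1170 nM together with the step of a 1.7-fold higher number from compound 1 to compound 2 (0.22 log units; within the scatter).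

Compound 4 is therefore expected to give 1800 nM in this assay, with an expected range from 900 nM to 3600 nM. That estimate means an expected step of a 1.5-fold higher number from compound 3 to compound 4 (0.19 log units; within the scatter), of roughly the size seen before.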

Compound 4, half-maximal inhibitory concentration: 3460 nM
Estimate against measurement, compound 4: 1.9-fold (0.28 log units) below, and the stated range covers the measured number.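

In this assay, the step from the 2-chlorophenyl to the 2,4-dichlorophenyl group gives a 3.0-fold higher number from compound 3 to compound 4 (0.47 log units; beyond the scatter), so on this core the added chloro brings a step beyond the scatter, whereas the earlier step stayed within it. Set side by side, the two steps point the same way and cannot be told apart in size: the same change on two cores in this assay, a 1.7-fold higher number (0.22 log units; within the scatter) from compound 1 to compound 2 and a 3.0-fold higher number (0.47 log units; beyond the scatter) from compound 3 to compound 4, 1.8-fold (0.25 log units) apart, within the scatter of two such steps With the two dichlorophenyl compounds, the shorter chain on the amine leaves a 1.4-fold higher number from compound 2 to compound 4 (0.13 log units; within the scatter), which fits the change carrying over in direction from one core to the other, but two instances do not fix its size, and the chloro enters at a different place in each, so they show no rule for the series.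

What the compounds shown leave open is whether a fluoro, methyl or methoxy group in place of the entering chloro would give a step of the same direction on these two cores. It is equally open how the same change would read with a longer chain than the two shown, or with a morpholine or piperidine in place of the dimethylamino group at the end of the chain.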